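The compounds below may be only part of what the source reports. "The series", "measured", "known", "first", "only" and "open" are said of these compounds alone.

In a functional assay on MES-SA cells (Homo sapiens) for inhibition, with a stated time of 72 h, in the presence of a further agent that is not named here (a lower number here means a stronger inhibitor, a higher number a weaker inhibitor), the measured compounds read as follows:
- Compound 1 `Oc1c(CN2CCCC2)ccc2cccnc12` gives 3980 nM; 3980 nM (2 entries)
- Compound 2 `COCc1cc(CN2CCCC2)c(O)c2ncccc12` gives 10500 nM
- Compound 3 `COCc1cc(CN2CCCCC2)c(O)c2ncccc12` gives 9550 nM

Compound 3 stands level with compound 2, as a 1.1-fold lower number from compound 2 to compound 3 (0.04 log units; within the scatter) shows, and both carry higher numbers than compound 1. Compound 4 `CCCOCc1cc(CN2CCCCC2)c(O)c2ncccc12` follows from compound 3 through the change ethyl in place of hydrogen on a saturated chain carbon bound to an oxygen on a saturated carbon that turns methoxymethyl into propoxymethyl. Within the data shown here, no measured step touches this chain. Among the measured compounds shown here, the one step available is the piperidin-1-yl for pyrrolidin-1-yl exchange, a different change, and it offers only weak guidance. No step beyond the scatter is therefore expected in this assay for this change. The estimate means a 1.2-fold lower number from compound 3 to compound 4 (0.08 log units; within the scatter) as the expected step. For compound 4 the estimate is 8000 nM as the middle value, with 3500 nM to 18000 nM as the expected range.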

Compound 4, half-maximal inhibitory concentration: 3550 nM
Beside the measured number, compound 4's estimate is 2.3-fold (0.35 log units) above it, within the range that was stated.
By their numbers in this assay, from the lowest: compound 4; then compounds 3 and 2 (each within the scatter of the next).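

In this assay, among these compounds, the change from methoxymethyl to propoxymethyl gives a 2.7-fold lower number from compound 3 to compound 4 (0.43 log units; beyond the scatter) and so moves the number beyond the scatter, which the one earlier step, a 1.1-fold lower number from compound 2 to compound 3 (0.04 log units; within the scatter), did not do. This chain therefore accepts ethyl in place of hydrogen and gives a modestly stronger inhibitor. No measurement here accounts for this step.

From the compounds shown here alone, whether a longer chain such as butoxymethyl would carry the step further remains open. So does the effect of an amine or a carboxylic acid at the end of this chain.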